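The compounds below may be only part of what the source reports. "The series", "measured", "known", "first", "only" and "open" are said of these compounds alone.

Among the compounds with values here, in a functional assay on HCT-15 cells (Homo sapiens) for inhibition (a lower number here means a stronger inhibitor of growth, a higher number a weaker inhibitor of growth), compound 3, drawn as `C=C1CCCC(C)(C)C1CC[C@@]1(C)CC[C@H]([C@@H](C)C(=O)O)OO1`, gives 10700 nM, and this is the only value among the three measured compounds that is a number rather than a limit. Compound 1, the methyl ester `COC(=O)[C@H](C)[C@H]1CC[C@@](C)(CCC2=C(C)CCCC2(C)C)OO1`, reaches only the limit > 25000 nM in this assay, as the limit of > 25000 nM in this assay, at which 1 of the 3 values shown sits, records. Compound 2, with the different core `C=C1CCC[C@H]2[C@](C)(CCC(C)=O)[C@@H](C)CC[C@]12C`, also stops at a limit, > 15000 nM, as the limit of > 15000 nM in this assay, at which 1 of the 3 values shown sits, records. Compound 4, `C=C1CCCC(C)(C)C1CC[C@]1(C)CC[C@@H]([C@@H](C)C(=O)O)OO1`, keeps every atom and bond of compound 3 and differs only in drawn configuration: the two compounds have the same atoms and bonds; at least one stereo element is drawn with a configuration in one of them and without one in the other: 2 of 4 stereo elements differ; a stereocentre at a saturated ring carbon is drawn S in compound 3 and R in compound 4; a stereocentre at a saturated ring carbon is drawn R in compound 3 and S in compound 4. Within the data shown here, no measured pair shows what such a change does here, so the step of no change at the digits printed from compound 3 to compound 4 (within the scatter) is expected to stay within the usual scatter, in neither direction. Compound 4 is therefore estimated at 10700 nM, between 3500 nM and 32000 nM.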

Compound 4, concentration for 50% growth inhibition: > 10000 nM
Compound 4 gave a limit, no number; the forecaster's own chance of this, stated with the estimate: 25%; the middle value is on the limit's open side.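

In this assay, within the data shown here, compound 4 gives only a limit, not a number, so no step from compound 3 to compound 4 can be read. The compounds shown leave open whether reversing these two ring stereocentres changes growth inhibition at all.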